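Triazole chalcone series: pentyl for methoxy on the aryl ring

A few compounds are considered here, and "the series" means these few. Any claim that something is new, unique, unknown or untested is made for them only; others in the source may bear on it.

Measured so far in a functional assay on RAW264.7 cells (Mus musculus) for inhibition, with a stated time of 4 days; a higher number here means a weaker inhibitor, a lower number a stronger inhibitor:
compound 1 `CCCCCc1ccc(-c2cn(-c3cccc(C(=O)/C=C/c4ccc(O)c(OC)c4)c3)nn2)cc1` gives 5780 nM
compound 2 `C=C(C)c1cn(-c2cccc(C(=O)/C=C/c3ccc(OC)c(O)c3)c2)nn1` gives 7760 nM
compound 3 `COc1ccc(-c2cn(-c3cccc(C(=O)/C=C/c4ccc(OC)c(O)c4)c3)nn2)cc1` gives 6290 nM

Compound 3 stands second highest of the three numbers; its nearest neighbour is compound 1 and its furthest is compound 2, and both gaps lie within the scatter. For the measured compounds named here, the only single-point step among the measured compounds is a 1.2-fold lower number from compound 2 to compound 3 (0.09 log units; within the scatter), which is within the scatter.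

Compound 4 `CCCCCc1ccc(-c2cn(-c3cccc(C(=O)/C=C/c4ccc(OC)c(O)c4)c3)nn2)cc1` is not yet measured. It differs from compound 3 in one place: pentyl in place of methoxy on an aromatic carbon. Going by the values given here, no measured step makes this exact change. Compound 1 carries the 4-pentylphenyl group but on a partner with hydroxy and methoxy exchanged; its value and that of compound 3 lie within the scatter of each other. Among the compounds with values here, the one measured step, a 1.2-fold lower number from compound 2 to compound 3 (0.09 log units; within the scatter), is also within the scatter. The series has so far moved little, so the step of a 1.1-fold lower number from compound 3 to compound 4 (0.03 log units; within the scatter) is expected to stay within the scatter. Compound 4 is therefore estimated at 5900 nM, in the range 3000 nM to 12000 nM.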

Compound 4, half-maximal inhibitory concentration: > 30000 nM
Compound 4: no number, only a limit; the forecaster's own chance of this, stated with the estimate: 5%; middle value at least 5.0-fold (0.70 log units) from the limit.
By their numbers in this assay, from the lowest: compounds 1, 3 and 2 (each within the scatter of the next). At a limit, above all of these: compound 4.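

In this assay the aromatic carbon that carries methoxy in compound 3 proves sensitive: pentyl there gives an at least 4.7-fold higher number from compound 3 to compound 4 (0.67 log units; beyond the scatter), and 4-pentylphenyl in place of 1-methylethenyl gives an at least 3.8-fold higher number from compound 2 to compound 4 (0.58 log units; beyond the scatter), whereas 4-methoxyphenyl in place of 1-methylethenyl had stayed within the scatter. Pentyl does not act alone: with 4-pentylphenyl kept, 3-hydroxy-4-methoxyphenyl in place of 4-hydroxy-3-methoxyphenyl gives an at least 5.1-fold higher number from compound 1 to compound 4 (0.71 log units; beyond the scatter), so among the compounds shown the loss appears only with this pairing of groups. All three steps are bounds only, and compound 4 has a limit rather than a number: the limit of > 30000 nM in this assay, at which 1 of the 4 values shown sits.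

Going by these compounds, the true size of these steps stays open. Also open, on these data alone, is whether a butyl chain or an amine in place of pentyl would return a value close to that of compound 3.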